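Swapping a Ring Substituent on a Fatty Acid Receptor Antagonist

This account rests on a few compounds, and the source may have more. Where it says the series, first, only, none or still open, it means among the compounds named here.

Of the compounds shown here, two sharing one core have been tested in a functional assay on cells for antagonist activity at Free fatty acid receptor 1 (Homo sapiens), read by TR-FRET and inositol phosphate accumulation, with a stated time of 2 h; a higher number here means a weaker inhibitor, a lower number a stronger inhibitor. Compound 1 `Cc1cc(COc2ccc(C#N)cc2)nc(-c2ccccn2)n1` gives 31600 nM in this assay, while compound 2 `CC1(C)CN(c2cc(COc3ccc(F)c(F)c3F)nc(-c3ccccn3)n2)C1` gives 25.1 nM. For the measured compounds named here, compound 2 therefore stands at the lowest of the two numbers, with compound 1 the only neighbour, and the gap between them lies far beyond the usual scatter of repeated measurements. Compound 2 is thus the stronger inhibitor of the pair.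

Compound 3 `N#CCC1(COc2cc(COc3ccc(F)c(F)c3F)nc(-c3ccccn3)n2)COC1` has not yet been measured. It differs from compound 2 in one place: (3-(cyanomethyl)oxetan-3-yl)methoxy in place of 3,3-dimethylazetidin-1-yl on an aromatic carbon. Going by the values given here, no single-point step between two measured compounds has been recorded, so there is nothing to borrow a size from. The change keeps a four-membered ring at the same position on the core but replaces a group bearing a nitrogen attached to the ring with one tethered through oxygen and carrying a nitrile.

The step from compound 2 to compound 3 is expected to be a modest weakening, a 3.2-fold higher number from compound 2 to compound 3 (0.50 log units; beyond the scatter), though the direction is uncertain. Compound 3 is estimated at 80 nM in this assay, within a range of 15 nM to 500 nM.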

Compound 3, half-maximal inhibitory concentration: 398 nM
Compound 3: the middle estimate sits 5.0-fold (0.70 log units) below what was measured; measured number inside the range.
By their numbers in this assay, from the lowest: compound 2; then compound 3; then compound 1.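

With everything else in the molecule held fixed, placing (3-(cyanomethyl)oxetan-3-yl)methoxy where 3,3-dimethylazetidin-1-yl stood gives a 16-fold higher number from compound 2 to compound 3 (1.20 log units; beyond the scatter) in this assay, so this position is sensitive to the group it carries. Keeping a four-membered non-aromatic ring with one hetero atom at this place is clearly not enough to preserve the value of compound 2, since the two groups share that ring yet differ widely in their numbers. No measurement shown here accounts for the size of this step, and the change alters several things at once: the entering group is larger, holds more hydrogen-bond acceptors, includes a nitrile and is joined to the core through oxygen rather than nitrogen.

The compounds shown leave open which of these differences matters, whether it is the nitrile, the oxetane ring or the oxygen tether. A plain methoxy group or a dimethylamino group at this position would be a simpler comparison, as would an azetidine ring joined through nitrogen and carrying a cyanomethyl group.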